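Ester to acid on two cores: cytotoxicity notes

The source may hold more compounds than are shown below. What is called first, only, known or untested is meant among the compounds shown, and "the series" means these compounds.

Measured so far in a functional assay on ECV-304 cells (Homo sapiens) for cytotoxicity, read by MTT assay, with stated times of 24 h and 12 h; a lower number here means that less compound is needed, a higher number that more compound is needed for the effect:
compound 1 `CCOC(=O)/C=C/c1ccc(OCc2nc(C)c(C)nc2C)c(O)c1`: 139000 nM
compound 2 `CCOC(=O)/C=C/c1cc(OC)c(OCc2nc(C)c(C)nc2C)c(OC)c1`: 2310000 nM
compound 3 `Cc1nc(C)c(COc2ccc(/C=C/C(=O)O)cc2O)nc1C`: 46000 nM

Compound 3 is compound 1 with hydrogen in place of ethyl on an oxygen next to a carbonyl group, and this change gave a 3.0-fold lower number from compound 1 to compound 3 (0.48 log units; beyond the scatter). Compound 2 sits highest of the three values; the difference between the core of compound 1 and the core of compound 2 is not broken down here, beyond what the two structures show.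

Compound 4 `COc1cc(/C=C/C(=O)O)cc(OC)c1OCc1nc(C)c(C)nc1C` has not been measured. It is compound 2 with hydrogen in place of ethyl on an oxygen next to a carbonyl group, the same change as from compound 1 to compound 3, at the same kind of place, and the two place descriptions agree word for word.

For this assay the step from compound 2 to compound 4 is expected at a 2.7-fold lower number from compound 2 to compound 4 (0.43 log units; beyond the scatter), set beside the earlier step of a 3.0-fold lower number from compound 1 to compound 3 (0.48 log units; beyond the scatter). The range is kept wide because compound 2 already gives 2310000 nM on a core whose difference from compound 1 is not broken down, so the ester-to-acid step is carried over only as a rough guide. Compound 4 is therefore estimated at 850000 nM, with a likely span from 300000 nM to 2500000 nM.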

Compound 4, half-maximal effective concentration: 3530000 nM
The estimate for compound 4 lay 4.2-fold (0.62 log units) below the measured number; the whole stated range lies below it.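

The change from ethoxycarbonyl to carboxy on the core of compound 2 gives, in this assay, a 1.5-fold higher number from compound 2 to compound 4 (0.18 log units; within the scatter), so on this core the step cannot be told apart from repeat measurement. The step therefore does not carry over unchanged between the two cores: the same change on two cores in this assay, a 3.0-fold lower number (0.48 log units; beyond the scatter) from compound 1 to compound 3 and a 1.5-fold higher number (0.18 log units; within the scatter) from compound 2 to compound 4, 4.6-fold (0.66 log units) apart, beyond the scatter of two such steps. This shows that, for these two pairs, the outcome of the change depends on the core it is made on; it does not show which structural difference between the two cores matters, and two cores give no rule for predicting a third.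

The compounds shown leave open whether a core carrying one methoxy group and a hydroxy group would follow the step seen on the core of compound 1 or that seen on the core of compound 2. They also leave open how an amide or a longer ester chain in place of ethoxycarbonyl would read on either core in this assay.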